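The source may report more compounds than this note shows. Statements on the series, on what has been measured and on what is new or still open speak of the compounds shown alone.

Three analogues of the shared core carry an aryl group on the amide-type nitrogen. In a functional assay (QGY7701 cells, Homo sapiens) for inhibition, read by MTT assay, with a stated time of 48 h (a higher number here means a weaker inhibitor, a lower number a stronger inhibitor), compound 1 `COc1ccc2c(=O)c(/C=C/C(=O)Nc3ccc(Cl)cc3)coc2c1` gives > 100000 nM, a limit of the assay rather than a number. Compound 2 `COc1ccc(NC(=O)/C=C/c2coc3cc(OC)ccc3c2=O)cc1` in this assay likewise returns only the limit > 100000 nM. Compound 3 `COc1ccc2c(=O)c(/C=C/C(=O)Nc3cccc(C)c3)coc2c1` also stands at the limit, > 100000 nM in this assay. Hence (the limit of > 100000 nM in this assay, at which 3 of the 3 values shown sit). Within the data shown here, the steps a step that the two limits leave unreadable from compound 1 to compound 2, a step that the two limits leave unreadable from compound 1 to compound 3 and a step that the two limits leave unreadable from compound 2 to compound 3 have no readable size, so the change 2,4-difluorobenzyl in place of 3-methylphenyl on an amide-type nitrogen that gives compound 4 `COc1ccc2c(=O)c(/C=C/C(=O)NCc3ccc(F)cc3F)coc2c1` has no measured precedent. Because of the limit of > 100000 nM in this assay, at which 3 of the 3 values shown sit, no departure from the limit is expected for compound 4. Compound 4 is therefore estimated at 150000 nM, in the range 100000 nM to 300000 nM. The expected step is a step that the limit leaves unreadable from compound 3 to compound 4.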

Compound 4, half-maximal inhibitory concentration: > 100000 nM
Compound 4 gave a limit, no number (the forecaster's own chance of this, stated with the estimate: 85%); the middle value lies beyond the limit too.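

Compound 4 also stands at a limit, so its steps from compound 1, compound 2 and compound 3 cannot be read: the limit of > 100000 nM in this assay, at which 4 of the 4 values shown sit. The compounds shown leave open whether any group on the amide-type nitrogen of the shared core gives a readable value in this assay.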